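Replacing cyclopropylamino with propylsulfanyl on the shared core

The compounds below may be only part of what the source reports. "The series", "measured", "known", "first", "only" and "open" are said of these compounds alone.

Among the compounds with values here, compound 3 `Nc1nc(NC2CC2)c2ncn(/C=C3/C[C@@H]3CO)c2n1` stands highest of the three measured so far in a functional assay on HFF cells (Homo sapiens) for cytotoxicity (on this read-out higher numbers stand for lower toxicity in this test and lower numbers for higher toxicity in this test), with 213000 nM. Compound 1 `CCCCCOc1nc(N)nc2c1ncn2/C=C1/C[C@@H]1CO` gives 41900 nM, and compound 2 `COc1nc(N)nc2c1ncn2/C=C1/C[C@@H]1CO` gives 15800 nM. The steps leading into compound 3 are a 5.1-fold higher number from compound 1 to compound 3 (0.71 log units; beyond the scatter) and a 13-fold higher number from compound 2 to compound 3 (1.13 log units; beyond the scatter); between the two chain ethers the step is a 2.7-fold lower number from compound 1 to compound 2 (0.42 log units; beyond the scatter). Compound 4 `CCCSc1nc(N)nc2c1ncn2/C=C1/C[C@@H]1CO` differs from compound 3 by propylsulfanyl in place of cyclopropylamino on an aromatic carbon. Within the data shown here, both chain-type groups measured on this aromatic carbon, in compound 1 and compound 2, sit well below compound 3, so a chain-type group entering here is expected to bring the number down, though no sulfur-linked group has yet been measured. Compound 4 is therefore expected near 35000 nM, within 12000 nM to 110000 nM, which would mean a 6.1-fold lower number from compound 3 to compound 4 (0.78 log units; beyond the scatter).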

Compound 4, half-maximal cytotoxic concentration: 283000 nM
Compound 4: middle estimate off by 8.1-fold (0.91 log units), on the low side; the whole stated range lies below it.
By their numbers in this assay, from the lowest: compound 2; then compound 1; then compounds 3 and 4 (each within the scatter of the next).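

In this assay the new result is a 1.3-fold higher number from compound 3 to compound 4 (0.12 log units; within the scatter) and so propylsulfanyl and cyclopropylamino stand level on this aromatic carbon, showing that a ring and a hydrogen-bond donor are not required for a number in this range. Propylsulfanyl also stands apart from the two oxygen-linked chains, with an 18-fold higher number from compound 2 to compound 4 (1.25 log units; beyond the scatter) against methoxy and a 6.8-fold higher number from compound 1 to compound 4 (0.83 log units; beyond the scatter) against pentyloxy. Nothing measured accounts for this gap. Open, as far as these compounds go, is whether propoxy, the oxygen counterpart of propylsulfanyl, falls with compound 1 or compound 4. Also open, from the compounds shown here alone, is whether a longer sulfur-linked chain such as pentylsulfanyl stays level with compound 4.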